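Phenyl for cyanofluorophenyl on the thiazole acetic acid series

The source may report more compounds than this note shows. Statements on the series, on what has been measured and on what is new or still open speak of the compounds shown alone.

Three compounds in this series have been run in an in vitro functional assay on HEK285-7 cells for antagonist activity at prostaglandin D2 receptor 2 (Homo sapiens), read by BRET and beta-arrestin recruitment; a higher number here means a larger maximal response, a lower number a smaller maximal response. Compound 1, `O=C(O)Cc1sc(COc2ccc(Cl)cc2)nc1-c1ccc(Cl)cc1`, gives 50%. Compound 2, `N#Cc1cc(-c2nc(C(c3ccc(F)cc3)c3ccc(F)cc3)sc2CC(=O)O)ccc1F`, gives 80%. Compound 3, `O=C(O)Cc1sc(C(c2ccccc2)c2ccccc2)nc1-c1ccccc1`, gives 80%. Compound 2 and compound 3 thus share the same number at the digits recorded, a pair within the scatter, and together they sit at the top of the three values; compound 1 lies well under compound 2, a gap that goes beyond the scatter.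

The next compound, compound 4, `O=C(O)Cc1sc(C(c2ccc(F)cc2)c2ccc(F)cc2)nc1-c1ccccc1`, has not yet been measured in this assay . It differs from compound 2 in one place: phenyl in place of 3-cyano-4-fluorophenyl on an aromatic carbon

Among the compounds with values here, no step between two measured compounds along this exact change is available, so the expectation rests on the values themselves. Compound 3, which also carries a plain phenyl at the aromatic carbon of the five-membered ring, gives 80%, and compound 2 gives 80%; both are level. On that basis the step of no change at the digits printed from compound 2 to compound 4 (within the scatter) is expected to stay within the scatter, with no direction to it. Compound 4 is therefore estimated at 80%, with a range from 66% to 92%.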

Compound 4, largest response reached (reported as efficacy), in percent of the reference or control that the assay uses: 80%
Compound 4: middle estimate and measured number agree at the digits printed; the range from low to high includes it.
By their numbers in this assay, from the lowest: compound 1; then compounds 2, 3 and 4 (each within the scatter of the next).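

In this assay, the replacement of 3-cyano-4-fluorophenyl by phenyl on the aromatic carbon next to the ring nitrogen reads as no change at the digits printed from compound 2 to compound 4 (within the scatter), which gives this series its first direct one-place comparison at this position. For this pair, the maximal response stays within the scatter although the substituent loses the nitrile, the ring fluorine and the hydrogen-bond acceptor counted for it, going from 9 heavy atoms to 6, so neither substituent on that aromatic ring is needed to hold the level seen with compound 2, while the finding stays limited to this one pair and says nothing yet of other substituents at this carbon. No measurement at hand accounts for this outcome.

Still open, from the compounds shown here alone, is how the nitrile and the fluorine each behave alone, since they leave together in this step, and a 3-cyanophenyl or a 4-fluorophenyl at this carbon would separate them. Also open, going by these compounds, is whether this position tolerates a different kind of group, such as a cyclohexyl ring, a pyridine ring or a substituent bearing an amine, with the rest of compound 4 held fixed.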